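Amino for Hydrogen on Two Benzyl-Purine Cores

This account rests on a few compounds, and the source may have more. Where it says the series, first, only, none or still open, it means among the compounds named here.

Compound 1 `ClCc1ccc(Cn2cnc3c(Cl)ncnc32)cc1`: 22900 nM
Compound 2 `Nc1nc(Cl)c2ncn(Cc3ccc(CCl)cc3)c2n1`: 97700 nM
Compound 3 `ClCc1ccccc1Cn1cnc2c(Cl)ncnc21`: 95500 nM

Of the compounds shown here, three have been measured in a functional assay on TK-10 cells (Homo sapiens) for cytotoxicity, read by sulforhodamine B assay, with a stated time of 48 h; on this read-out lower numbers stand for higher toxicity in this test and higher numbers for lower toxicity in this test. Compound 1 gives 22900 nM, while compound 2, which carries amino in place of hydrogen on an aromatic carbon, gives 97700 nM. That single change produced a 4.3-fold higher number from compound 1 to compound 2 (0.63 log units; beyond the scatter). Compound 3 gives 95500 nM; its value and that of compound 2 lie within the scatter of each other, whereas against compound 1 the gap is beyond the scatter. Compound 3 and compound 1 are built from the same atoms joined differently, and the difference between the two cores is not broken down here.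

Compound 4 `Nc1nc(Cl)c2ncn(Cc3ccccc3CCl)c2n1` has not yet been measured. It differs from compound 3 by amino in place of hydrogen on an aromatic carbon, the same change that turned compound 1 into compound 2. If that change acts alike on the core of compound 3, compound 4 is expected to show a 2.6-fold higher number from compound 3 to compound 4 (0.42 log units; beyond the scatter), an expectation resting on the step of a 4.3-fold higher number from compound 1 to compound 2 (0.63 log units; beyond the scatter). Compound 4 is therefore estimated at 250000 nM, between 90000 nM and 700000 nM, with a real chance that this assay returns only a limit.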

Compound 4, concentration lethal to 50% of the cells: 75900 nM
Estimate against measurement, compound 4: 3.3-fold (0.52 log units) above; the whole stated range lies above it.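

Amino in place of hydrogen on an aromatic carbon did not repeat its earlier effect in this assay, where the new step is a 1.3-fold lower number from compound 3 to compound 4 (0.10 log units; within the scatter). Set beside the earlier step, the two results differ clearly: the same change on two cores in this assay, a 4.3-fold higher number (0.63 log units; beyond the scatter) from compound 1 to compound 2 and a 1.3-fold lower number (0.10 log units; within the scatter) from compound 3 to compound 4, 5.4-fold (0.73 log units) apart, beyond the scatter of two such steps

In this series, then, the size of the step seen on one core could not be carried over to the other, and a step read on a single core proved a poor guide to the same change elsewhere. Within the data shown here, with only two such pairs, however, this does not show which feature of the cores separates the two results, nor how the change would behave on any further core.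

On these data alone, it remains open whether a methylamino group or a hydroxyl group on the same aromatic carbon would follow the amino group on either core. Also open, as far as these compounds go, is whether a methoxy group in place of the chloro group would leave the two cores as far apart in this assay.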